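Compound 3 to compound 4: methoxy out, chloro in

The source may hold more compounds than are shown below. What is called first, only, known or untested is meant among the compounds shown, and "the series" means these compounds.

In a functional assay on A549 cells (Homo sapiens) for inhibition, read by CCK-8 assay, with a stated time of 72 h, tested at 1 uM (on this read-out higher numbers stand for more inhibition of growth at the one concentration tested and lower numbers for less inhibition of growth), compound 1 (`CN(C)C(=O)c1cc2cnc(Nc3ccc(NC(=O)C4(C(=O)Nc5ccc(F)cc5)CC4)cc3)nc2n1C1CCCC1`) gives 86.6%, compound 2 (`CN(C)C(=O)c1cc2cnc(Nc3ccc(NC(=O)C4(C(=O)Nc5ccc(Cl)cc5)CC4)cc3)nc2n1C1CCCC1`) gives 24.7% and compound 3 (`COc1ccc(NC(=O)C2(C(=O)Nc3ccc(Nc4ncc5cc(C(=O)N(C)C)n(C6CCCC6)c5n4)cc3)CC2)cc1`) gives 74.4%, second highest of the three. Compound 4 (`CN(C)C(=O)c1cc2cnc(Nc3ccc(NC(=O)C4(C(=O)Nc5ccc(Cl)c(C(F)(F)F)c5)CC4)cc3)nc2n1C1CCCC1`) carries 4-chloro-3-(trifluoromethyl)phenyl in place of 4-methoxyphenyl on an amide-type nitrogen. Two large steps involve chloro: a number 61.9 percentage points lower from compound 1 to compound 2 (beyond the scatter) and a number 49.7 percentage points higher from compound 2 to compound 3 (beyond the scatter). The modest a number 12.2 percentage points lower from compound 1 to compound 3 (beyond the scatter) involves no chloro. Among the compounds with values here, no measured compound carries trifluoromethyl, so the estimate is loose. A large step downward is expected, as a number 36.4 percentage points lower from compound 3 to compound 4 (beyond the scatter). For compound 4 the estimated value is 38%, with an expected range from 12% to 70%.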

Compound 4, percent growth inhibition at one concentration: 1.1%
Compound 4: middle estimate off by 36.9 percentage points, on the high side; measured number outside the range, below it.
By their numbers in this assay, from the lowest: compound 4; then compound 2; then compound 3; then compound 1.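

In this assay there is a number 23.6 percentage points lower from compound 2 to compound 4 (beyond the scatter) once trifluoromethyl replaces hydrogen on an aromatic carbon, so adding to the chloro-bearing aryl group lowers growth inhibition further. The full replacement on the amide-type nitrogen gives a number 73.3 percentage points lower from compound 3 to compound 4 (beyond the scatter) and also a number 85.5 percentage points lower from compound 1 to compound 4 (beyond the scatter) in this series. No measurement at hand accounts for these losses. From the compounds shown here alone, whether trifluoromethyl without chloro also lowers the number remains open. So does the reading for an aryl group carrying an amine or a carboxylic acid at this amide-type nitrogen.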